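This account rests on a few compounds, and the source may have more. Where it says the series, first, only, none or still open, it means among the compounds named here.

Measured so far in a functional assay on HGC-27 cells (Homo sapiens) for cytotoxicity, read by MTT assay, with a stated time of 72 h; on this read-out higher numbers stand for weaker inhibition and lower numbers for stronger inhibition:

Compound 1 `CCCCCCNc1nc(SCc2ccc(C(F)(F)F)cc2)nc2ccccc12`: 23900 nM
Compound 2 `CCCCCCCCCCCCCCNc1nc(SCc2ccc(C(F)(F)F)cc2)nc2ccccc12`: > 50000 nM
Compound 3 `CCOc1ccccc1Nc1nc(SCc2ccc(C(F)(F)F)cc2)nc2ccccc12`: > 50000 nM

Compound 3 has no exact number in this assay; its value is a limit of the assay, the limit described in the limit of > 50000 nM in this assay, at which 2 of the 3 values shown sit. Compound 2 also sits at that limit. Compound 1 is the only one of the three with a measured number, and the steps away from it, an at least 2.0-fold higher number from compound 1 to compound 2 (0.32 log units; beyond the scatter) and an at least 2.0-fold higher number from compound 1 to compound 3 (0.32 log units; beyond the scatter), both go towards weaker inhibition and reach the limit.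

Compound 4 `O=[N+]([O-])c1cccc(Nc2nc(SCc3ccc(C(F)(F)F)cc3)nc3ccccc23)c1` differs from compound 3 in one place: 3-nitrophenyl in place of 2-ethoxyphenyl on a nitrogen on an aromatic ring. Going by the values given here, no measured step among the three compounds swaps one group on that aromatic-ring nitrogen for another of the same kind, so the only guidance is that compound 3 itself is already at the limit and that the step of an at least 2.0-fold higher number from compound 1 to compound 3 (0.32 log units; beyond the scatter) showed the shared core tolerating a change on that nitrogen only with loss of inhibition.

Compound 4 is therefore expected to stay near the limit, with the step that the limit leaves unreadable from compound 3 to compound 4 most likely not resolvable beyond the scatter. The estimate for compound 4 is 60000 nM, with a range from 20000 nM to 200000 nM, and a high chance that only a limit is reported.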

Compound 4, half-maximal inhibitory concentration: > 50000 nM
Compound 4: a limit, no number; the forecaster's own chance of this, stated with the estimate: 65%; the middle value lies beyond the limit too.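

In this assay, putting 3-nitrophenyl in place of hexyl on the nitrogen gives an at least 2.0-fold higher number from compound 1 to compound 4 (0.32 log units; beyond the scatter). Two different substituted phenyl groups on this nitrogen, 2-ethoxyphenyl in compound 3 and 3-nitrophenyl in compound 4, now both read weaker than the hexyl group of compound 1, so the earlier result for compound 3 is no longer a single case. The direct swap between these two phenyl groups cannot be read, and the compounds shown give no order between them, because both values are limits and not numbers: the limit of > 50000 nM in this assay, at which 3 of the 4 values shown sit.

Compound 1 remains the only one of the four with a measured number, which leaves open whether any phenyl group on this nitrogen can give a readable value in this assay, for instance an unsubstituted phenyl or a benzyl. Going by these compounds, it is also open how the chains between hexyl and the tetradecyl of compound 2 would read, such as an octyl or a decyl, and whether a shorter butyl would keep, lose or improve the inhibition seen with compound 1.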